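This account rests on a few compounds, and the source may have more. Where it says the series, first, only, none or still open, it means among the compounds named here.

Series notes, bile acid receptor binding.

Compound 1 `COC(=O)/C=C/c1ccc(CN(C(=O)C2CCCCC2)c2cccc(/C=C/C(=O)OC)c2)cc1` is the reference of the first pair. In an assay on isolated protein with Bile acid receptor (Homo sapiens) as the target (on this read-out higher numbers stand for an effect only at larger amounts of compound and lower numbers for an effect already at smaller amounts), compound 1 gives only a limit of the assay, > 1000 nM. Compound 2 `COC(=O)/C=C/c1cccc(N(Cc2ccc(/C=C/C(=O)OCc3ccccc3)cc2)C(=O)C2CCCCC2)c1` carries phenyl in place of hydrogen on a saturated chain carbon bound to an oxygen next to a carbonyl group. In this assay compound 2 likewise gives only a limit, > 1000 nM. The step that the two limits leave unreadable from compound 1 to compound 2 therefore cannot be sized, because both values sit at the limit of > 1000 nM in this assay, at which 3 of the 3 values shown sit.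

Compound 3 `COC(=O)/C=C/c1cccc(N(Cc2ccc(/C=C/C(=O)OC(C)(C)C)cc2OC)C(=O)C2CCCCC2)c1` is the reference of the second pair; the difference between its core and the core of compound 1 is not broken down here. In this assay compound 3 gives only a limit, > 1000 nM. Compound 4 `COC(=O)/C=C/c1cccc(N(Cc2ccc(/C=C/C(=O)OC(C)(C)C)cc2OCc2ccccc2)C(=O)C2CCCCC2)c1` carries phenyl in place of hydrogen on a saturated chain carbon bound to an oxygen on an aromatic ring. Among the compounds with values here, this is the same kind of change as the one from compound 1 to compound 2, but the place differs: in the first pair the saturated chain carbon is bound to an oxygen next to a carbonyl group, in the second pair it is bound to an oxygen on an aromatic ring.

Within the data shown here, the only evidence for this kind of change is the unreadable step from compound 1 to compound 2, and all three values so far rest at the limit of > 1000 nM in this assay, at which 3 of the 3 values shown sit. No readable step is available on which to expect a change of any size. For compound 4 the step that the limit leaves unreadable from compound 3 to compound 4 is estimated to be small. In this assay compound 4 is expected to give 2000 nM, most likely again only a limit, with a range of 500 nM to 10000 nM.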

Compound 4, half-maximal effective concentration: > 1000 nM
Compound 4 gave a limit, no number; the forecaster's own chance of this, stated with the estimate: 80%; the middle value does not contradict the limit.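

In this assay compound 3 and compound 4 each give only a limit of the assay, so no step can be read between them, and the series stays where it was: the limit of > 1000 nM in this assay, at which 4 of the 4 values shown sit.

The compounds shown leave open what size of effect, if any, the change from methoxy to benzyloxy has, and at what concentration any of these compounds would reach the half-maximal effect.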